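A few compounds are considered here, and "the series" means these few. Any claim that something is new, unique, unknown or untested is made for them only; others in the source may bear on it.

Three compounds have been measured in a toxicity assay on A549 cells (Homo sapiens) for cytotoxicity, read by luminescence and CellTiter-Glo, with a stated time of 48 h; on this read-out higher numbers stand for lower toxicity in this test and lower numbers for higher toxicity in this test:

Compound 1, `CCCCOc1ccc(-c2c(NC(C)(C)CC(C)(C)C)nc3ncccn23)cc1`, gives 49000 nM.
Compound 2, `CC(C)(C)CC(C)(C)Nc1nc2ncccn2c1-c1ccc(Br)cc1`, gives > 100000 nM, which is a limit of the assay and not a number.
Compound 3, `CCCCOc1ccc(-c2nc3ncccn3c2Nc2ccccc2)c(C)c1`, gives 23000 nM.

Compound 1 and compound 2 share one core and differ in a single place: bromo in place of butoxy on an aromatic carbon. The measured step is an at least 2.0-fold higher number from compound 1 to compound 2 (0.30 log units; that floor lies within the scatter). The value of compound 2 is a limit, and (the limit of > 100000 nM in this assay, at which 1 of the 3 values shown sits). Compound 3 is built on a different core; the difference between the two cores is not broken down here. In this assay compound 3 has the lower of the two numbers, and compound 1 stands nearest to it.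

Compound 4, `Cc1cc(Br)ccc1-c1nc2ncccn2c1Nc1ccccc1`, has not yet been measured. From compound 3 to compound 4 the change is bromo in place of butoxy on an aromatic carbon. Compared with the change from compound 1 to compound 2, the place is not quite the same: in compound 4 the entering bromo sits meta to a methyl group, which has no counterpart in compound 2, so this is the same kind of change rather than the same change.

Compound 4 is expected to show a step of a 2.4-fold higher number from compound 3 to compound 4 (0.38 log units; beyond the scatter) in this assay, resting on the earlier step of an at least 2.0-fold higher number from compound 1 to compound 2 (0.30 log units; that floor lies within the scatter). Compound 4 is therefore estimated at 55000 nM, with a likely range from 18000 nM to 200000 nM. A reported limit rather than a number would not be surprising for compound 4 given (the limit of > 100000 nM in this assay, at which 1 of the 3 values shown sits).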

Compound 4, half-maximal cytotoxic concentration: 40000 nM
Compound 4: middle estimate off by 1.4-fold (0.14 log units), on the high side, and the stated range covers the measured number.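

Bromo in place of butoxy on the core of compound 3 gives a 1.7-fold higher number from compound 3 to compound 4 (0.24 log units; within the scatter) in this assay, so on this core the swap cannot be told apart from the ordinary spread between repeated measurements. Set beside the same swap on the core of compound 1, this result neither confirms nor rules out that the change keeps its size from one core to the other: the same change on two cores in this assay, an at least 2.0-fold higher number (0.30 log units; that floor lies within the scatter) from compound 1 to compound 2 and a 1.7-fold higher number (0.24 log units; within the scatter) from compound 3 to compound 4; the limit leaves it open whether they differ Two pairs are too few to make a rule for the series, and neither printed step lies beyond the scatter, so these compounds show no firm effect of the swap on toxicity in this test, on either core.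

The compounds shown leave open how the read-out would respond to other groups at this place on either core, such as a methoxy group, a chlorine atom, an amine or a carboxylic acid. They also leave open whether the swap would give a similar step on a third core, and whether the methyl group carried by compound 3 and compound 4 plays any part in their step.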